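Isopropyl on the carbamoyl nitrogen of a trimethoxybenzyl triazole

The compounds below may be only part of what the source reports. "The series", "measured", "known", "first", "only" and "open" are said of these compounds alone.

Of the compounds shown here, two sharing a piperazine dithiocarbamate core have been tested in a functional assay on SMMC-7721 cells (Homo sapiens) for cytotoxicity, read by MTT assay, with a stated time of 72 h; on this read-out lower numbers stand for stronger inhibition and higher numbers for weaker inhibition. Compound 1 `COc1ccc(Cn2cc(CSC(=S)N3CCN(C(N)=O)CC3)nn2)cc1` carries a single methoxy group on its benzyl ring, and in this assay compound 1 gives > 128000 nM, which is a limit of the assay rather than a number. Compound 2 `COc1cc(Cn2cc(CSC(=S)N3CCN(C(N)=O)CC3)nn2)cc(OC)c1OC` carries three methoxy groups instead, and in this assay compound 2 gives > 128000 nM, again a limit of the assay and not a number. Both values therefore sit at the same boundary, as the evidence notes: the limit of > 128000 nM in this assay, at which 2 of the 2 values shown sit. Compound 2 thus stands at the limit, with no measured number to place it.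

Compound 3 `COc1cc(Cn2cc(CSC(=S)N3CCN(C(=O)NC(C)C)CC3)nn2)cc(OC)c1OC` differs from compound 2 by isopropyl in place of hydrogen on an amide-type nitrogen. Among the measured compounds shown here, no measured step shows what such a change does, so any expectation rests on the limit values alone. Compound 3 is expected to give about 128000 nM, within a range from 40000 nM to 300000 nM. The expected step of a number no higher from compound 2 to compound 3 (the limit leaves the size open) is estimated to be none beyond the scatter, since compound 2 gives only a limit in this assay.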

Compound 3, half-maximal inhibitory concentration: > 128000 nM
Compound 3 gave a limit, no number (the forecaster's own chance of this, stated with the estimate: 70%); the middle value lies on the limit itself.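

In this assay compound 3 gives > 128000 nM, a limit of the assay and not a number. No step from compound 2 to compound 3 can be read, because both compounds stand at a limit: the limit of > 128000 nM in this assay, at which 3 of the 3 values shown sit.

The compounds shown leave open what isopropyl in place of hydrogen on an amide-type nitrogen does in this assay.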